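A few compounds are considered here, and "the series" means these few. Any claim that something is new, unique, unknown or untested is made for them only; others in the source may bear on it.

In a functional assay on SW480 cells (Homo sapiens) for antiproliferative activity, read by MTT assay, with a stated time of 48 h (on this read-out lower numbers stand for stronger inhibition and higher numbers for weaker inhibition), compound 1 `CCCCCC(CCO)n1cnc2c(NC)ncnc21` reports only a limit, > 50000 nM. Compound 2 `CCCCCCCC(CCO)n1cnc2c(NC)ncnc21` gives 15300 nM. Compound 3 `CCCCCCCCCCC(CCO)n1cnc2c(OC)ncnc21`, with a longer chain, gives 8260 nM, which lies within the usual scatter of compound 2. Compound 4 `CCCCCCCCCCC(CCO)n1cnc2c(NC)ncnc21` keeps the chain of compound 3 and changes one group (methylamino in place of methoxy on an aromatic carbon), with methylamino in place of methoxy on an aromatic carbon. Among the compounds with values here, the only measured step, an at least 3.2-fold lower number from compound 1 to compound 2 (0.51 log units; beyond the scatter), alters the chain and leaves this group untouched, so no measured step shows what the swap does. No step beyond the scatter is therefore expected, and the estimated step is a 1.4-fold lower number from compound 3 to compound 4 (0.14 log units; within the scatter). For compound 4 the expected value is 6000 nM, with an estimated range of 2500 nM to 15000 nM.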

Compound 4, half-maximal inhibitory concentration: 12000 nM
Compound 4: the middle estimate sits 2.0-fold (0.30 log units) below what was measured; the measured number falls inside the stated range.
By their numbers in this assay, from the lowest: compounds 3, 4 and 2 (each within the scatter of the next). At a limit, above all of these: compound 1.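

In this assay, methylamino in place of methoxy on an aromatic carbon gives a 1.5-fold higher number from compound 3 to compound 4 (0.16 log units; within the scatter), so at this position, adding a hydrogen-bond donor leaves no readable change. Within the data shown here, with methylamino kept, propyl on the chain gives a 1.3-fold lower number from compound 2 to compound 4 (0.11 log units; within the scatter), while pentyl gives an at least 4.1-fold lower number from compound 1 to compound 4 (0.61 log units; beyond the scatter), the only one of these steps beyond the scatter. Compound 1 is a limit, not a number: the limit of > 50000 nM in this assay, at which 1 of the 4 values shown sits.

Open, going by these compounds, is what a plain amino group, an ethoxy group or a chlorine atom on this aromatic carbon would give. Also open, on these data alone, is whether a longer chain than that of compound 4 would lower the number.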